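One Carbon Shorter: From Compound 3 to Compound 4

The source may report more compounds than this note shows. Statements on the series, on what has been measured and on what is new or still open speak of the compounds shown alone.

Of the compounds shown here, three have been measured in a functional assay on NCI-H1975 cells (Homo sapiens) for antiproliferative activity, read by MTT assay, with a stated time of 72 h; a lower number here means a stronger inhibitor, a higher number a weaker inhibitor. Compound 1 `CN(C)C/C=C/C(=O)Nc1cc2ncnc(Nc3ccc(F)c(Cl)c3)c2cc1O[C@@H]1CCOC1` gives 740 nM, compound 2 `C=CC(=O)Nc1cc2c(Nc3cccc(Cl)c3F)ncnc2cc1OCc1cn(CCC(=O)NO)nn1` gives 6610 nM, and compound 3 `C=CC(=O)Nc1cc2c(Nc3ccc(OCc4cccc(F)c4)c(Cl)c3)ncnc2cc1OCc1cn(CCCC(=O)NO)nn1` gives 12000 nM, the highest of the three numbers. Compound 3 and compound 2 lie within the scatter of each other, while compound 1 sits far lower, beyond the scatter. Compound 4 `C=CC(=O)Nc1cc2c(Nc3ccc(OCc4cccc(F)c4)c(Cl)c3)ncnc2cc1OCc1cn(CCC(=O)NO)nn1` differs from compound 3 in one place: hydroxycarbamoyl in place of (hydroxycarbamoyl)methyl on a saturated chain carbon, two bonds along the chain from an aromatic nitrogen. For the measured compounds named here, no step between measured compounds isolates this kind of change, so there is no basis for expecting movement beyond the scatter in either direction. The step from compound 3 to compound 4 is expected to be a 1.2-fold lower number from compound 3 to compound 4 (0.08 log units; within the scatter). Compound 4 is estimated at 10000 nM, with a range from 4000 nM to 25000 nM.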

Compound 4, half-maximal inhibitory concentration: 21000 nM
Estimate against measurement, compound 4: 2.1-fold (0.32 log units) below; measured number inside the range.
By their numbers in this assay, from the lowest: compound 1; then compounds 2, 3 and 4 (each within the scatter of the next, the first and the last beyond it).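

Swapping 3-(hydroxycarbamoyl)propyl for 2-(hydroxycarbamoyl)ethyl on the triazole gives a 1.8-fold higher number from compound 3 to compound 4 (0.24 log units; within the scatter) in this assay, the only step shown that isolates the length of this chain. At these two lengths, then, the chain makes no readable difference, and both compounds remain in the same weak range. Nothing measured here offers an explanation for this result. Still open, on these data alone, is whether a longer chain, such as 4-(hydroxycarbamoyl)butyl, would read any differently. Also open, as far as these compounds go, is whether a carboxylic acid or a primary amide in place of the hydroxycarbamoyl end would shift the number beyond the scatter.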